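Cytotoxicity notes on the butoxyphenyl series: compound 3

This account rests on a few compounds, and the source may have more. Where it says the series, first, only, none or still open, it means among the compounds named here.

Measured so far:
compound 1 `CCCCOc1ccc(-c2nc3ncccn3c2NCC2CC2)cc1` — > 100000 nM
compound 2 `CCCCOc1ccc(-c2nc3ncccn3c2NCc2nc[nH]c2C)cc1` — 100000 nM

For the measured compounds named here, in a toxicity assay on A549 cells (Homo sapiens) for cytotoxicity, read by luminescence and CellTiter-Glo, with a stated time of 48 h (a lower number here means that less compound is tolerated, a higher number that more compound is tolerated), compound 2 gives 100000 nM, the only number in the set. For compound 1 the assay reports a limit rather than a number, > 100000 nM. Going by the values given here, the one measured step, a number no higher from compound 1 to compound 2 (the limit leaves the size open), therefore has no readable size, because one of its two values sits at the limit of > 100000 nM in this assay, at which 1 of the 2 values shown sits; it concerns the group on the saturated chain carbon bound to the ring nitrogen, not the imidazole substituent.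

Compound 3 `CCCCOc1ccc(-c2nc3ncccn3c2NCc2c[nH]cn2)cc1` differs from compound 2 by hydrogen in place of methyl on an aromatic carbon. No measured step touches this position, and the single step shown has an open size, so the measured steps give no direction for the change. Compound 2 already sits at the top of the measured range, and the expected step of no change at the digits printed from compound 2 to compound 3 (within the scatter) is estimated to be nothing beyond the scatter. Compound 3 is accordingly estimated at 100000 nM, with a range from 50000 nM to 200000 nM, and a real chance that the assay again reports only a limit.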

Compound 3, half-maximal cytotoxic concentration: > 100000 nM
Compound 3: no number, only a limit (the forecaster's own chance of this, stated with the estimate: 50%); the middle value sits exactly at the limit.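

Taking the methyl off the 5-methyl-1H-imidazol-4-yl group gives a number no lower from compound 2 to compound 3 (the limit leaves the size open) and so, in this assay, hydrogen on this aromatic carbon shows no sign of less compound being tolerated than with methyl. Compound 3 gives > 100000 nM as a limit of the assay, not a number. Neither this step nor the step from the cyclopropyl group of compound 1 to the 1H-imidazol-4-yl group of compound 3 can be read for size, so this position cannot be ranked, because most of the series sits at one ceiling: the limit of > 100000 nM in this assay, at which 2 of the 3 values shown sit.

Still open, going by these compounds, is whether any change at this aromatic carbon, such as an amine or a carboxylic acid in place of the hydrogen, would bring the result down to a readable number. Equally open, on these data alone, is whether a longer chain in place of the butoxy group would do so, since a change that gives a number below the limit is what would make steps measurable.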